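The compounds below may be only part of what the source reports. "The series", "measured", "known", "first", "only" and "open" are said of these compounds alone.

In a functional assay on KBVIN cells (Homo sapiens) for inhibition, read by sulforhodamine B assay, with a stated time of 72 h (a lower number here means a stronger inhibitor of growth, a higher number a weaker inhibitor of growth), compound 1 `C=C1CC[C@@H]2[C@](C)(COC(=O)CCCCC3CCSS3)[C@H](OC(=O)CCCCC3CCSS3)CC[C@@]2(C)[C@@H]1/C=C/C1=CCOC1=O` gives 12900 nM and compound 2 `C=C1CC[C@@H]2[C@](C)(COC(=O)C3CCCN3C(=O)OC(C)(C)C)[C@H](O)CC[C@@]2(C)[C@@H]1/C=C/C1=CCOC1=O` gives 17900 nM and these two values lie within the usual scatter of each other. Among the measured compounds shown here, compound 2 therefore stands level with the only other measured compound. Compound 3 `C=C1CC[C@@H]2[C@](C)(COC(=O)CCCCC3CCSS3)[C@H](O)CC[C@@]2(C)[C@@H]1/C=C/C1=CCOC1=O` differs from compound 2 in one place on a carbonyl carbon, and the change is this: a group of 9 heavy atoms (7 carbon, 2 sulfur; one five-membered non-aromatic ring with 2 hetero atoms) in place of a group of 12 heavy atoms (9 carbon, 1 nitrogen, 2 oxygen; one five-membered non-aromatic ring with 1 hetero atom), on a carbonyl carbon while the shared core stays as it is. For the measured compounds named here, no measured pair shows this change alone, so no step can be read directly. Compound 1 also carries the entering group, and at 12900 nM it sits within the scatter of compound 2. No shift beyond the scatter is therefore expected in this assay in either direction. The estimate means an expected 1.5-fold lower number from compound 2 to compound 3 (0.17 log units; within the scatter) and that stays within the scatter. Compound 3 is estimated at 12000 nM (expected range 4500 nM to 30000 nM).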

Compound 3, concentration for 50% growth inhibition: > 30000 nM
Compound 3 gave a limit, no number (the forecaster's own chance of this, stated with the estimate: 15%); middle value at least 2.5-fold (0.39 log units) away from the limit.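

The result for compound 3 is a limit, not a number: the limit of > 30000 nM in this assay, at which 1 of the 3 values shown sits. At the carbonyl carbon, replacing 1-(tert-butoxycarbonyl)pyrrolidin-2-yl with the group carrying the two-sulfur ring gives an at least 1.6-fold higher number from compound 2 to compound 3 (0.22 log units; that floor lies within the scatter), so this step alone does not establish a real change, although the true gap could be larger. Among the compounds shown here, the other step is the first to clear the scatter: with a hydrogen in place of the second two-sulfur ring group, on an oxygen on a saturated carbon, the data show an at least 2.3-fold higher number from compound 1 to compound 3 (0.36 log units; beyond the scatter), so in this pair the ester group on that oxygen goes with stronger growth inhibition.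

From the compounds shown here alone, how far compound 3 lies past its limit remains open, so neither step has a true size. Also open, going by these compounds, is whether the two-sulfur ring itself matters on that oxygen, or whether a plain acetyl group or an amine-bearing chain there would serve equally well.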